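The source may hold more compounds than are shown below. What is called first, only, known or untested is meant among the compounds shown, and "the series" means these compounds.

Compound 1 `CCN(Cc1cccs1)C(=O)c1cc2cc(C)ccc2o1` gives 120 nM in an assay on HEK293 cells for agonist activity at transient receptor potential cation channel subfamily M member 8 (Homo sapiens), read by fluorescence and calcium flux, with a stated time of 15 min (a lower number here means that less compound is needed, a higher number that more compound is needed for the effect), the second highest of the three numbers at hand. Compound 3 `CCN(Cc1cccs1)C(=O)COc1ccccc1C` gives 192 nM, within the scatter of compound 1, while compound 2 `Cc1ccc2oc(C(=O)N(Cc3cccs3)c3ccn[nH]3)cc2c1` gives 40 nM; a 3.0-fold lower number from compound 1 to compound 2 (0.48 log units; beyond the scatter) went with a 1H-pyrazol-5-yl in place of ethyl on an amide-type nitrogen. Compound 4 `CCN(Cc1cccs1)C(=O)c1cc2cc(OC)ccc2o1` differs from compound 1 by methoxy in place of methyl on an aromatic carbon. No measured step touches this position: the single step shown concerns the amide nitrogen and does not bear on an exchange on the aromatic ring, so nothing in the data argues for a shift in either direction. Compound 4 is therefore expected to show no step beyond the scatter no change at the digits printed from compound 1 to compound 4 (within the scatter). The estimate for compound 4 in this assay is 120 nM, between 50 nM and 300 nM.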

Compound 4, half-maximal effective concentration in the transient receptor potential cation channel subfamily M member 8 assay: 80 nM
For compound 4 the middle estimate is 1.5-fold (0.18 log units) above the measured one, within the range that was stated.
By their numbers in the transient receptor potential cation channel subfamily M member 8 assay, from the lowest: compounds 2, 4, 1 and 3 (each within the scatter of the next, the first and the last beyond it).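

Among these compounds, in the transient receptor potential cation channel subfamily M member 8 assay the first exchange at this aromatic carbon gives a 1.5-fold lower number from compound 1 to compound 4 (0.18 log units; within the scatter) and so stays within the scatter, whereas the step at the amide nitrogen (a 3.0-fold lower number from compound 1 to compound 2 (0.48 log units; beyond the scatter)) lay beyond it. In a physicochemical assay for solubility, measured as thermodynamic solubility, at pH 7.1 (on this read-out higher numbers stand for higher solubility and lower numbers for lower solubility), compound 1 gives 27000 nM and compound 4 gives 49000 nM so that the same exchange gives a 1.8-fold higher number from compound 1 to compound 4 (0.26 log units; within the scatter) and also stays within the scatter. Nothing at hand offers an explanation for either step. Going by these compounds, whether an amine, a carboxylic acid or a longer chain at this position would move either number beyond the scatter stays open, as does whether methoxy would behave the same way alongside the 1H-pyrazol-5-yl group.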